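Rat plasma stability: hydroxy in place of methyl

The source may report more compounds than this note shows. Statements on the series, on what has been measured and on what is new or still open speak of the compounds shown alone.

In an ADME assay on a cell-free system (plasma, Rattus norvegicus) for metabolic stability, read by LC-MS, with a stated time of 60 min, tested at 100 uM (a higher number here means that more of the compound is left, a lower number that less of the compound is left), compound 2 (`Cc1c(OCCCCOc2cccc(C(=O)O)c2)ccc(C(=O)CC(C)C)c1C`) gives 106%, level with compound 1 (`Cc1c(OCCCCOc2ccc(C(=O)O)cc2F)ccc(C(=O)CC(C)C)c1O`) at 106%, within the scatter. Compound 3 (`Cc1c(OCCCCOc2cccc(C(=O)O)c2)ccc(C(=O)CC(C)C)c1O`) carries hydroxy in place of methyl on an aromatic carbon, ortho to an isobutylcarbonyl group: hydroxy in place of methyl on an aromatic carbon. Among the measured compounds shown here, no step between measured compounds isolates this change. No shift beyond the scatter is expected, since compound 1, which also holds hydroxy on that carbon, gives 106%. The expected a number 4 percentage points lower from compound 2 to compound 3 (within the scatter) stays within the scatter. For compound 3 the estimated value is 102%, with an expected range of 91% to 112%.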

Compound 3, percent of the compound remaining: 100%
Beside the measured number, compound 3's estimate is 2 percentage points above it; the range from low to high includes it.
By their numbers in this assay, from the lowest: compounds 3, 1 and 2 (each within the scatter of the next).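

In this assay, hydroxy in place of methyl on an aromatic carbon, ortho to an isobutylcarbonyl group, now has a direct step: a number 6 percentage points lower from compound 2 to compound 3 (within the scatter). The change from 4-carboxy-2-fluorophenyl to 3-carboxyphenyl on an oxygen on a saturated carbon also has its first step: a number 6 percentage points lower from compound 1 to compound 3 (within the scatter). Neither change moves the read-out beyond the scatter, and no supporting evidence bears on this result. The compounds shown leave open whether an amine or a methoxy group on that aromatic carbon would also stay within the scatter. They also leave open how a compound without the carboxylic acid would read.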